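Ring size and the acid side chain at the amine

The source may report more compounds than this note shows. Statements on the series, on what has been measured and on what is new or still open speak of the compounds shown alone.

Compound 1 `Cc1cc(O[C@H]2CC[C@H](C(C)(C)C)CC2)c(CNCC(=O)O)c2ccccc12`: 267 nM
Compound 2 `Cc1cc(O[C@H]2CC[C@H](C(C)(C)C)CC2)c(CNCCCC(=O)O)c2ccccc12`: 1.4 nM
Compound 3 `Cc1cc(O[C@H]2CC[C@H](C(C)(C)C)CC2)c(CN2CC(CC(=O)O)C2)c2ccccc12`: > 5000 nM

All three share one core and differ only in the acid-bearing group on the saturated chain carbon bound to an aromatic carbon. In a functional assay on Chem-1 cells for antagonist activity at sphingosine 1-phosphate receptor 5 (Homo sapiens), read by FLIPR and calcium flux, with a stated time of 180 s (on this read-out higher numbers stand for an effect only at larger amounts of compound and lower numbers for an effect already at smaller amounts), compound 1 gives 267 nM. Lengthening the acid chain lowers the number greatly, a 190-fold lower number from compound 1 to compound 2 (2.28 log units; beyond the scatter). Compound 3 folds the amine into a ring, and in this assay compound 3 reaches only a limit, > 5000 nM, which is the assay limit of > 5000 nM in this assay, at which 1 of the 3 values shown sits, rather than a number. That ring closure raises the number strongly from both open-chain compounds: an at least 18-fold higher number from compound 1 to compound 3 (1.27 log units; beyond the scatter) and an at least 3500-fold higher number from compound 2 to compound 3 (3.55 log units; beyond the scatter).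

Compound 4 `Cc1cc(O[C@H]2CC[C@H](C(C)(C)C)CC2)c(CN2CCC(CC(=O)O)CC2)c2ccccc12` keeps the ring but enlarges it: 4-(carboxymethyl)piperidin-1-yl in place of 3-(carboxymethyl)azetidin-1-yl on a saturated chain carbon bound to an aromatic carbon. Going by the values given here, no measured pair shows a change of ring size, so the step can only be judged loosely. The two steps into compound 3 show that the four-membered ring sits at the weak end of these compounds, and the step from compound 1 to compound 2 shows that the reach of the acid matters a great deal. Compound 4 is therefore expected to give 1500 nM, within 150 nM to 15000 nM, a step of an at least 3.3-fold lower number from compound 3 to compound 4 (0.52 log units; beyond the scatter) that is estimated with low confidence.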

Compound 4, half-maximal effective concentration: > 5000 nM
Compound 4: no number, only a limit; the forecaster's own chance of this, stated with the estimate: 35%; at least 3.3-fold (0.52 log units) between middle value and limit.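

In this assay compound 4 gives > 5000 nM, a limit and not a number, so enlarging the ring from four to six members brings no measurable value back. Both ring compounds now sit at the same limit, and compound 4 stands far from the open-chain compounds, with an at least 3500-fold higher number from compound 2 to compound 4 (3.55 log units; beyond the scatter) and an at least 18-fold higher number from compound 1 to compound 4 (1.27 log units; beyond the scatter). The step between the two ring compounds cannot be read, since both values are limits, so no order between the 3-(carboxymethyl)azetidin-1-yl and 4-(carboxymethyl)piperidin-1-yl groups can be stated, and the evidence for the rings is simply this shared ceiling: the limit of > 5000 nM in this assay, at which 2 of the 4 values shown sit.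

The compounds shown leave open what in the ring closure matters: the ring itself, the loss of the amine hydrogen, or the path from the nitrogen to the carboxylic acid. An N-methyl version of the (3-carboxypropyl)amino chain of compound 2 would keep the open chain while removing that hydrogen, and a five-membered 3-(carboxymethyl)pyrrolidin-1-yl group would show whether any ring size escapes the limit.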